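From 2-fluorophenyl to 4-fluorophenyl on the shared core

The compounds below may be only part of what the source reports. "The series", "measured", "known", "first", "only" and "open" are said of these compounds alone.

In a functional assay on WM1361 cells (Homo sapiens) for inhibition, read by MTT assay, with a stated time of 24 h (on this read-out higher numbers stand for weaker inhibition and lower numbers for stronger inhibition), compound 3 `O=c1oc2ccccc2c(N2CCN(c3ccccc3F)CC2)c1CO` gives > 50000 nM, which is a limit of the assay and not a number. On the same core, compound 1 `O=c1oc2ccccc2c(N2CCN(c3cccc(Cl)c3Cl)CC2)c1CO` gives 45900 nM and compound 2 `COc1cccc(N2CCN(c3c(CO)c(=O)oc4ccccc34)CC2)c1` gives 38100 nM. Compound 4 `O=c1oc2ccccc2c(N2CCN(c3ccc(F)cc3)CC2)c1CO` carries 4-fluorophenyl in place of 2-fluorophenyl on an amine nitrogen in a ring. Three exchanges at this same place bear on the change: a 1.2-fold lower number from compound 1 to compound 2 (0.08 log units; within the scatter), an at least 1.0-fold higher number from compound 1 to compound 3 (0.03 log units; that floor lies within the scatter) and an at least 1.3-fold higher number from compound 2 to compound 3 (0.11 log units; that floor lies within the scatter). The first lies within the scatter, and the other two are floors that lie within it. No step beyond the scatter is therefore expected in this assay. The estimated step is a number no higher from compound 3 to compound 4 (the limit leaves the size open). For compound 4 the estimated value is 50000 nM, with an expected range from 30000 nM to 85000 nM.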

Compound 4, half-maximal inhibitory concentration: > 50000 nM
Compound 4 gave a limit, no number; the forecaster's own chance of this, stated with the estimate: 50%; the middle value lies on the limit itself.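

In this assay, the change from 2-fluorophenyl to 4-fluorophenyl gives no readable result: the step between compound 3 and compound 4 cannot be read, as both values are limits of the assay and not numbers. The comparisons with the two other compounds give an at least 1.3-fold higher number from compound 2 to compound 4 (0.11 log units; that floor lies within the scatter) and an at least 1.0-fold higher number from compound 1 to compound 4 (0.03 log units; that floor lies within the scatter), so neither separates compound 4 from them. Compound 3 and compound 4 end at the same boundary of the read-out: the limit of > 50000 nM in this assay, at which 2 of the 4 values shown sit.

As far as these compounds go, whether any group at this place can give a value well inside the measurable range stays open. A phenyl bearing an amine or a carboxylic acid would be one such test.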